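The compounds below may be only part of what the source reports. "The series", "measured", "known", "first", "only" and "open" are said of these compounds alone.

an ADME assay on MT4 cells (Homo sapiens) for cytotoxicity, read by XTT assay, with a stated time of 3 days (a lower number here means that less compound is tolerated, a higher number that more compound is tolerated), gives these values so far:

compound 1 `Cc1cc(C)cc(Cc2c(I)c(=O)[nH]c(=O)n2COCc2ccccc2)c1` gives 98300 nM
compound 2 `CN(C)c1c(Cc2ccccc2)n(COCc2ccccc2)c(=O)[nH]c1=O` gives 91800 nM

Compound 2 stands level with compound 1 within the usual scatter of repeated measurements. For the measured compounds named here, compound 3 `Cc1cc(C)cc(Cc2c(N(C)C)c(=O)[nH]c(=O)n2COCc2ccccc2)c1` differs from compound 2 by having 3,5-dimethylphenyl in place of phenyl on a saturated chain carbon bound to an aromatic carbon as its one change. Going by the values given here, no step between measured compounds shows the effect of this change in this assay so no step beyond the scatter is expected in either direction. The estimated step of a 1.1-fold lower number from compound 2 to compound 3 (0.03 log units; within the scatter) is correspondingly small. For compound 3 the expected value is 85000 nM with 40000 nM to 130000 nM as its expected range.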

Compound 3, half-maximal cytotoxic concentration: 55800 nM
The estimate for compound 3 lay 1.5-fold (0.18 log units) above the measured number; the range from low to high includes it.
By their numbers in this assay, from the lowest: compounds 3, 2 and 1 (each within the scatter of the next).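

In this assay the step of a 1.6-fold lower number from compound 2 to compound 3 (0.22 log units; within the scatter) comes with 3,5-dimethylphenyl in place of phenyl on a saturated chain carbon bound to an aromatic carbon, and the step of a 1.8-fold lower number from compound 1 to compound 3 (0.25 log units; within the scatter) comes with dimethylamino in place of iodo on an aromatic carbon. Neither change therefore moves the number beyond ordinary repeat variation, so at both places these groups are tolerated alike. No supporting evidence bears on these results.

Still open, from the compounds shown here alone, is whether a carboxylic acid in place of dimethylamino on that aromatic carbon would give a real step. The same applies to a longer chain in place of benzyl.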